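Mirror Image of an Anilide Carbamate Lactone

The compounds below may be only part of what the source reports. "The series", "measured", "known", "first", "only" and "open" are said of these compounds alone.

Of the compounds shown here, two have been measured in a functional assay on RAW264.7 cells (Mus musculus) for inhibition, with a stated time of 30 min; on this read-out higher numbers stand for weaker inhibition and lower numbers for stronger inhibition. Compound 1 `C=C1C(=O)OC[C@H]1CCOC(=O)Nc1ccc(Br)cc1` gives 350 nM. Compound 2 `C=C1C(=O)OC[C@@H]1CCOC(=O)Nc1ccccc1` gives 780 nM, the higher of the two numbers. Compound 3 `C=C1C(=O)OC[C@H]1CCOC(=O)Nc1ccccc1` has not yet been measured; it differs from compound 2 as follows: the two compounds have the same atoms and bonds and differ only in configuration as drawn: 1 of 1 stereo elements differ; a stereocentre at a saturated ring carbon is drawn R in compound 2 and S in compound 3. Among the compounds with values here, no measured pair shows the effect of such a change, so the direction is uncertain; a step of moderate size in either direction, or none beyond the scatter, is possible. On balance compound 3 is expected to give 500 nM in this assay, between 120 nM and 2000 nM, a step from compound 2 to compound 3 of a 1.6-fold lower number from compound 2 to compound 3 (0.19 log units; within the scatter).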

Compound 3, half-maximal inhibitory concentration: 390 nM
For compound 3 the middle estimate is 1.3-fold (0.11 log units) above the measured one; measured number inside the range.
By their numbers in this assay, from the lowest: compounds 1, 3 and 2 (each within the scatter of the next, the first and the last beyond it).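

In this assay, the configuration at this saturated ring carbon can now be judged on its own, and the comparison is a clean one: the fact that compounds 2 and 3 differ only in the configuration as drawn. Inverting that stereocentre gives a 2.0-fold lower number from compound 2 to compound 3 (0.30 log units; within the scatter), so the R and S forms are not separated beyond the scatter. With the S configuration held, hydrogen in place of bromo gives a 1.1-fold higher number from compound 1 to compound 3 (0.05 log units; within the scatter), so this swap is not resolved either. The compounds shown leave open whether a methoxy group or a nitrile on that aromatic carbon, or a longer chain in the linker, would move the number beyond the scatter.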